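A few compounds are considered here, and "the series" means these few. Any claim that something is new, unique, unknown or untested is made for them only; others in the source may bear on it.

Three compounds that share one core and differ only in the ring on a saturated ring carbon have been tested in a functional assay on MDA-MB-468 cells (Homo sapiens) for antiproliferative activity, read by CellTiter-Glo, with a stated time of 96 h; on this read-out higher numbers stand for weaker inhibition and lower numbers for stronger inhibition. In this test compound 2 `COc1ccc(-c2nsc3c2NC(=O)CC3c2cccc(Cl)c2)cc1` gives 752 nM. Compound 1 `COc1ccc(-c2nsc3c2NC(=O)CC3c2ccc3c(c2)OCCO3)cc1` gives 451 nM, which lies within the usual scatter of the number for compound 2, so these two cannot be told apart. Compound 3 `COc1ccc(-c2nsc3c2NC(=O)CC3c2ccc(F)cc2)cc1` gives 1850 nM. Compound 2 therefore stands close to compound 1 and clearly apart from compound 3.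

Compound 4 `COc1ccc(-c2nsc3c2NC(=O)CC3c2ccsc2)cc1` has not yet been measured. It keeps the core of compound 2 and changes one group: thiophen-3-yl in place of 3-chlorophenyl on a saturated ring carbon. In words, thiophen-3-yl takes the place of 3-chlorophenyl on the same saturated ring carbon.

For the measured compounds named here, only one measured step starts from the same group at this place. Putting 4-fluorophenyl there gives a 2.5-fold higher number from compound 2 to compound 3 (0.39 log units; beyond the scatter), a modest change. Going by the values given here, no compound with a five-membered ring has been measured, so this guide is thin. A modest step toward a higher number, no larger than that one, is expected in this assay. The estimated step is a 1.5-fold higher number from compound 2 to compound 4 (0.17 log units; within the scatter). For compound 4 the estimate is 1100 nM, with an expected range from 400 nM to 3000 nM.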

Compound 4, half-maximal inhibitory concentration: 163 nM
Compound 4: middle estimate off by 6.7-fold (0.83 log units), on the high side; the whole stated range lies above it.
By their numbers in this assay, from the lowest: compound 4; then compounds 1 and 2 (each within the scatter of the next); then compound 3.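

At this saturated ring carbon, the ring can be swapped for a five-membered one without any loss: in this assay thiophen-3-yl gives a 4.6-fold lower number from compound 2 to compound 4 (0.66 log units; beyond the scatter) and, set against the 4-fluorophenyl group, an 11-fold lower number from compound 3 to compound 4 (1.05 log units; beyond the scatter). For the compounds shown here, the one earlier step from 3-chlorophenyl ran toward a higher number, so this result adds the first step in the opposite direction and shows that a change away from 3-chlorophenyl at this place can move the number either way. Going by these compounds alone, the large gap between compound 3 and compound 4 also shows that the choice of ring here matters a great deal in this assay, although a single thiophen-3-yl compound is the only example of a five-membered ring, so it sets no general rule.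

Nothing available explains why thiophen-3-yl gives the lower number. From the compounds shown here alone, it also remains open how the number would respond to an amine or a carboxylic acid carried on this ring, or to a plain alkyl chain standing in place of the ring on the same carbon.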